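The compounds below may be only part of what the source reports. "The series", "measured", "known", "first", "only" and "open" are said of these compounds alone.

Of the compounds shown here, three have been measured so far in an assay on CHO-K1 cells for displacement of a labelled ligand from 5-hydroxytryptamine receptor 6 (Homo sapiens), read by scintillation counting, with a stated time of 3 h; a higher number here means a weaker inhibitor, a lower number a stronger inhibitor. Compound 1 `O=C1CCCN1c1cnc2c(N3CCNCC3)cccc2c1` gives 4900 nM. Compound 2 `O=C1CC(c2ccccc2)CN1c1cnc2c(N3CCCNCC3)cccc2c1` gives 10 nM. Compound 3 `O=C1OC(c2ccccc2)CN1c1ccc2c(c1)CCNCC2` gives 16 nM. On these numbers compound 3 holds the second highest place of the three. Its nearest neighbour is compound 2, and the gap between the two lies within the usual scatter of repeated measurements, so they cannot be told apart on this evidence. Its furthest neighbour is compound 1, and that gap lies well beyond the scatter.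

The next compound, compound 4 `O=C1OC(c2ccccc2F)CN1c1ccc2c(c1)CCNCC2`, differs from compound 3 in one place only: fluoro in place of hydrogen on an aromatic carbon, which in words is fluoro in place of hydrogen on an aromatic carbon. For the measured compounds named here, no pair among the measured compounds isolates this change, so the numbers in hand give no direct reading of its size. The change is small, a single fluorine atom added to the phenyl, and a step that stays within the scatter, in either direction, is the expectation. The step of a 1.1-fold lower number from compound 3 to compound 4 (0.06 log units; within the scatter) is therefore estimated to be modest. Compound 4 is expected to give about 14 nM, with a range from 5 nM to 45 nM.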

Compound 4, inhibition constant: 15 nM
Estimate against measurement, compound 4: 1.1-fold (0.03 log units) below, and the stated range covers the measured number.
By their numbers in this assay, from the lowest: compounds 2, 4 and 3 (each within the scatter of the next); then compound 1.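

For the compounds shown here, the swap of phenyl for 2-fluorophenyl gives a 1.1-fold lower number from compound 3 to compound 4 (0.03 log units; within the scatter) in this assay and is the first step here that isolates a single change, since the earlier compounds differ from one another in more than one place. It shows that, on this core, a fluoro can replace hydrogen on this aromatic carbon, ortho to a large group, without moving the number beyond what repeat measurements would be expected to show, so compound 3 and compound 4 cannot be told apart in this assay. This is a reading of one atom at one place on one core, and nothing available speaks to the reason for the result.

The compounds shown leave open whether this position would accept something larger than fluoro, such as chloro, methoxy or trifluoromethyl, or a group of a different kind, such as an amine or a carboxylic acid. They also leave open whether fluoro would give the same reading on the other carbons of this phenyl ring, or on the phenyl of compound 2, whose core is different.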